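The compounds below may be only part of what the source reports. "The series", "measured", "known", "first", "only" and "open" are said of these compounds alone.

Series notes. Compound 1 `FC(F)(F)c1ccc(CSc2nc(Nc3ccccc3C(F)(F)F)c3ccccc3n2)cc1` and compound 2 `FC(F)(F)c1ccc(CSc2nc(Nc3cccc(Cl)c3)c3ccccc3n2)cc1` share one core and differ only in the substituted phenyl on a nitrogen on an aromatic ring. In a functional assay on PC-3 cells (Homo sapiens) for cytotoxicity, read by MTT assay, with a stated time of 72 h (on this read-out lower numbers stand for stronger inhibition and higher numbers for weaker inhibition), compound 1 gives 34800 nM, while compound 2 gives 13400 nM. For the measured compounds named here, compound 2 therefore carries the lowest of the two numbers so far, with compound 1 as its only neighbour, and the single measured step, a 2.6-fold lower number from compound 1 to compound 2 (0.41 log units; beyond the scatter), is modest though beyond the scatter. Compound 3 `COc1ccc(Nc2nc(SCc3ccc(C(F)(F)F)cc3)nc3ccccc23)cc1` is next: 4-methoxyphenyl in place of 3-chlorophenyl on a nitrogen on an aromatic ring. Going by the values given here, the only step with any bearing on it is that single one, since it also exchanges one substituted phenyl for another at the same place; it shows that such an exchange can move this assay by a modest amount, but one pair gives no direction for a different exchange. For compound 3 in this assay no step beyond the scatter is expected, a 1.3-fold higher number from compound 2 to compound 3 (0.13 log units; within the scatter). Compound 3 is estimated at 18000 nM, with a range from 7000 nM to 45000 nM.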

Compound 3, half-maximal inhibitory concentration: 16700 nM
Compound 3: middle estimate off by 1.1-fold (0.03 log units), on the high side, and the stated range covers the measured number.
By their numbers in this assay, from the lowest: compounds 2 and 3 (each within the scatter of the next); then compound 1.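

In this assay, 4-methoxyphenyl in place of 3-chlorophenyl on a nitrogen on an aromatic ring gives a 1.2-fold higher number from compound 2 to compound 3 (0.10 log units; within the scatter), so two groups that carry different substituents, with 0 and 1 hydrogen-bond acceptors, cannot be told apart at this position. The exchange of 2-(trifluoromethyl)phenyl now has a second reading, a 2.1-fold lower number from compound 1 to compound 3 (0.32 log units; beyond the scatter), which shows that compound 1 stands apart from compound 3 as well as from compound 2, although the step remains modest. No measurement at hand accounts for either step.

From the compounds shown here alone, with three compounds, it remains open whether the higher number of compound 1 belongs to the trifluoromethyl group itself or to where it sits on the phenyl, since the substituent and its place change together in these pairs. Also open, going by these compounds, is how this assay responds when the phenyl on this nitrogen carries an amine or a carboxylic acid, or gives way to a longer alkyl chain, and whether any change to the rest of the shared core moves the number further than these exchanges do.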